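Swapping Halogen Phenyl Groups on a Weak Antiproliferative Nucleoside

The compounds below may be only part of what the source reports. "The series", "measured", "known", "first", "only" and "open" are said of these compounds alone.

Two compounds share a core carrying a sugar and a varying aryl group. Compound 1 `Nc1ncnn2c([C@@H]3O[C@H](CO)[C@@H](O)[C@H]3O)cc(C#Cc3ccc(F)cc3)c12` bears a 2-(4-fluorophenyl)ethynyl group; in a functional assay on NCI-H460 cells (Homo sapiens) for antiproliferative activity, with a stated time of 72 h (a higher number here means a weaker inhibitor, a lower number a stronger inhibitor), compound 1 gives 79400 nM. Compound 2 `Nc1ncnn2c([C@@H]3O[C@H](CO)[C@@H](O)[C@H]3O)cc(-c3ccc(Cl)cc3)c12` carries 4-chlorophenyl instead, and in this assay compound 2 gives 45900 nM. For the measured compounds named here, the step of a 1.7-fold lower number from compound 1 to compound 2 (0.24 log units; within the scatter) is the only measured step so far. Compound 2 stands with the lowest of the two numbers, but its nearest neighbour, compound 1, lies within the scatter, so no ranking is claimed.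

Compound 3 `Nc1ncnn2c([C@@H]3O[C@H](CO)[C@@H](O)[C@H]3O)cc(-c3ccccc3F)c12` has not yet been measured. It differs from compound 2 as follows: 2-fluorophenyl in place of 4-chlorophenyl on an aromatic carbon. Going by the values given here, the only step that bears on this change is a 1.7-fold lower number from compound 1 to compound 2 (0.24 log units; within the scatter), which replaced the whole aryl group and stayed within the scatter. Nothing in the data points in either direction for the move from 4-chlorophenyl to 2-fluorophenyl. Compound 3 is therefore expected to give 50000 nM in this assay, within a range of 18000 nM to 140000 nM, an expected step of a 1.1-fold higher number from compound 2 to compound 3 (0.04 log units; within the scatter) that would stay within the scatter.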

Compound 3, half-maximal inhibitory concentration: > 100000 nM
Compound 3 gave a limit, no number; the forecaster's own chance of this, stated with the estimate: 25%; middle value at least 2.0-fold (0.30 log units) from the limit.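

In this assay compound 3 gives > 100000 nM as a limit and not a number. Even so, replacing 4-chlorophenyl with 2-fluorophenyl on this aromatic carbon gives an at least 2.1-fold higher number from compound 2 to compound 3 (0.33 log units; beyond the scatter) as the first step in the series beyond the scatter, which shows that the number can respond to a change between two aryl groups that have the same count of heavy atoms and the same kind of ring. The comparison with the longer 2-(4-fluorophenyl)ethynyl group stays unresolved, since an at least 1.2-fold higher number from compound 1 to compound 3 (0.10 log units; that floor lies within the scatter) gives only a floor that cannot place compound 1 and compound 3 in any order.

The step from compound 2 to compound 3 changes the halogen and its place on the phenyl ring at the same time, so these compounds cannot say which of the two matters, and a 4-fluorophenyl or a 2-chlorophenyl group would be needed to separate them. They also leave open how the number responds at this carbon to a group without a halogen, such as an unsubstituted phenyl ring, an amine or a carboxylic acid.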